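This account rests on a few compounds, and the source may have more. Where it says the series, first, only, none or still open, it means among the compounds named here.

Compound 1 `Nc1cccc(-c2cn(CC(=O)Nc3nccs3)nn2)c1` gives 1270 nM in a functional assay on BMDM cells (Mus musculus, strain C57BL/6) for inhibition, with a stated time of 2 days; on this read-out higher numbers stand for weaker inhibition and lower numbers for stronger inhibition.
Compound 2 `COC(=O)c1ccc(-c2cn(CC(=O)Nc3nc(C)cs3)nn2)cc1` gives > 30000 nM in this assay.

For compound 2 this value is a limit of the assay and not a number: compound 2 stands at the limit of > 30000 nM in this assay, at which 1 of the 2 values shown sits. Compound 3 `COc1ccc(-c2cn(CC(=O)Nc3nc(C)cs3)nn2)cc1` has not yet been measured. It differs from compound 2 in one place, (methoxy in place of methoxycarbonyl on an aromatic carbon). Among the measured compounds shown here, no measured pair shows this change, so the expected step from compound 2 to compound 3 is put at an at least 3.0-fold lower number from compound 2 to compound 3 (0.47 log units; beyond the scatter), toward stronger inhibition, in this assay. Compound 3 is expected to give about 10000 nM, between 2000 nM and 30000 nM, in this assay.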

Compound 3, half-maximal inhibitory concentration: 3890 nM
The estimate for compound 3 lay 2.6-fold (0.41 log units) above the measured number; measured number inside the range.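

Putting methoxy in place of methoxycarbonyl on this aromatic carbon, para to a large group, gives an at least 7.7-fold lower number from compound 2 to compound 3 (0.88 log units; beyond the scatter), toward stronger inhibition in this assay. Inhibition at this position can therefore be read as a number with methoxy, and the group here clearly matters. The true size of the step stays unknown because compound 2 gives only a limit of the assay: the limit of > 30000 nM in this assay, at which 1 of the 3 values shown sits.

The compounds shown leave open how a hydroxyl or a carboxylic acid at this position would compare with methoxy.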